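The source may hold more compounds than are shown below. What is called first, only, known or untested is meant among the compounds shown, and "the series" means these compounds.

Measured compounds:
compound 1 `O=C(/C=C/C(=O)N1C/C(=C\c2ccccc2)C(=O)/C(=C/c2ccccc2)C1)Nc1ccc([N+](=O)[O-])cc1` — 40000 nM
compound 2 `O=C(/C=C/C(=O)N1C/C(=C\c2ccc([N+](=O)[O-])cc2)C(=O)/C(=C/c2ccc([N+](=O)[O-])cc2)C1)Nc1ccc(Cl)c(Cl)c1` — 380 nM
compound 3 `CC(=O)c1ccc(NC(=O)/C=C/C(=O)N2C/C(=C\c3ccccc3)C(=O)/C(=C/c3ccccc3)C2)cc1` — 1700 nM

In a functional assay on CCRF-CEM cells (Homo sapiens) for cytotoxicity (a higher number here means a weaker inhibitor, a lower number a stronger inhibitor), compound 2 gives the lowest of the three numbers. The nearest value is that of compound 3, which gives 1700 nM in this assay, and the furthest is that of compound 1, which gives 40000 nM. Compound 2 differs from both in more than one place, so no single step can be read off against either of them.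

Compound 4 `Cc1ccc(NC(=O)/C=C/C(=O)N2C/C(=C\c3ccc([N+](=O)[O-])cc3)C(=O)/C(=C/c3ccc([N+](=O)[O-])cc3)C2)cc1C` has not been measured. It differs from compound 2 in one place: 3,4-dimethylphenyl in place of 3,4-dichlorophenyl on an amide-type nitrogen.

Among the compounds with values here, the only measured single step in this set, a 24-fold lower number from compound 1 to compound 3 (1.37 log units; beyond the scatter), also changes the substituent on the aryl group attached to the amide nitrogen, so it bears on the step from compound 2 to compound 4 and shows that a change at this place can move the number a great deal. It does not, however, involve chlorine or methyl, so it gives no direction for the present change. Compound 4 is therefore expected to be somewhat weaker than compound 2, with wide uncertainty, the expected step being a 2.4-fold higher number from compound 2 to compound 4 (0.37 log units; beyond the scatter). For compound 4 the estimate in this assay is 900 nM, expected to fall between 200 nM and 4000 nM.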

Compound 4, half-maximal inhibitory concentration: 700 nM
Estimate against measurement, compound 4: 1.3-fold (0.11 log units) above; the range from low to high includes it.
By their numbers in this assay, from the lowest: compounds 2 and 4 (each within the scatter of the next); then compound 3; then compound 1.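

In this assay, putting 3,4-dimethylphenyl in place of 3,4-dichlorophenyl on the amide-type nitrogen gives a 1.8-fold higher number from compound 2 to compound 4 (0.27 log units; within the scatter) and so leaves the two compounds level within the scatter. Within the data shown here, the earlier compounds showed only that a change on this aryl group could be large, with acetyl in place of nitro giving a 24-fold lower number from compound 1 to compound 3 (1.37 log units; beyond the scatter) on the core of compound 1. This pair adds the first case on the core of compound 2, and it shows that a change on this aryl group need not move the number: a group of carbon only and a group carrying two chlorine atoms, each with the same heavy-atom count, cannot be told apart here.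

From the compounds shown here alone, whether an amine or a carboxylic acid on this aryl group would also stay level with compound 2 remains open. So does whether the same exchange of 3,4-dichlorophenyl for 3,4-dimethylphenyl would read alike on the core of compound 1. Nothing measured in these data speaks to what lies behind the result.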